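The compounds below may be only part of what the source reports. "The series", "measured", "known", "first", "only" and "open" are said of these compounds alone.

Working notes on the series. Compound 1, `CCc1ccc(OCc2ccc(C(=O)Nc3ccccc3N)cc2)cc1`, carries an ethyl group on the outer ring of the shared core, and in a functional assay on HCT-116 cells (Homo sapiens) for antiproliferative activity, read by CCK-8 assay, with a stated time of 72 h (on this read-out higher numbers stand for weaker inhibition and lower numbers for stronger inhibition), compound 1 gives 4830 nM. Compound 2, `COc1ccc(OCc2ccc(C(=O)Nc3ccccc3N)cc2)cc1`, differs only in a methoxy in place of that ethyl, and in this assay compound 2 gives 2020 nM. Among the measured compounds shown here, compound 1 thus stands at the higher of the two numbers measured so far; the single step available, a 2.4-fold lower number from compound 1 to compound 2 (0.38 log units; beyond the scatter), is modest but beyond the scatter.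

The next compound, compound 3, `CCCc1ccc(OCc2ccc(C(=O)Nc3ccccc3N)cc2)cc1`, is reached from compound 1 by methyl in place of hydrogen on a saturated chain carbon, two bonds along the chain from an aromatic carbon. For the measured compounds named here, no measured step concerns this kind of change: the only step known swaps the ethyl for a methoxy and does not extend the chain, so it gives no direct guidance on lengthening ethyl to propyl. With nothing in the data pointing to a change in either direction, compound 3 is expected to land near compound 1 in this assay, with a step of about a 1.0-fold higher number from compound 1 to compound 3 (0.02 log units; within the scatter), which lies within the scatter. The estimate for compound 3 in this assay is therefore 5000 nM, with a range from 2000 nM to 12000 nM.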

Compound 3, half-maximal inhibitory concentration: 3230 nM
Beside the measured number, compound 3's estimate is 1.5-fold (0.19 log units) above it, and the stated range covers the measured number.
By their numbers in this assay, from the lowest: compounds 2, 3 and 1 (each within the scatter of the next, the first and the last beyond it).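

In this assay lengthening ethyl to propyl gives a 1.5-fold lower number from compound 1 to compound 3 (0.17 log units; within the scatter) and so adding a methyl on a saturated chain carbon, two bonds along the chain from an aromatic carbon, cannot be told from no change on this read-out. Propyl in place of methoxy on an aromatic carbon gives a 1.6-fold higher number from compound 2 to compound 3 (0.20 log units; within the scatter) and is equally unresolved, which places compound 3 within the scatter of both other compounds, while a 2.4-fold lower number from compound 1 to compound 2 (0.38 log units; beyond the scatter) remains the only step beyond the scatter among the three. No measurement at hand bears on why the chain extension reads this way.

As far as these compounds go, whether a longer chain such as butyl, or a branched one such as isopropyl, would stay within the scatter of compound 1 remains open, as does the outcome with an amine or a carboxylic acid on that same aromatic carbon. The compounds shown also leave open whether these small steps would hold outside this assay in another read-out.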